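The source may hold more compounds than are shown below. What is called first, only, known or untested is meant among the compounds shown, and "the series" means these compounds.

In a functional assay on NCI-H460 cells (Homo sapiens) for antiproliferative activity, with a stated time of 72 h (a higher number here means a weaker inhibitor, a lower number a stronger inhibitor), compound 3 (`C=CC[C@H]1C[C@]2([C@@H](C)Cc3ccc(O)cc3)OCOC2=CC1=O`) gives > 20000 nM as its reading, which is a limit of the assay and not a number. Among the three measured compounds it therefore stands at a limit only (the limit of > 20000 nM in this assay, at which 1 of the 3 values shown sits). In the same assay, compound 1 (`C=CC[C@H]1C[C@]2([C@@H](C)Cc3cccc(OC)c3)OCOC2=CC1=O`) gives 10600 nM and compound 2 (`C=CC[C@H]1C[C@]2([C@@H](C)Cc3ccccc3)OCOC2=CC1=O`) gives 9700 nM as their readings, and these two values lie within the scatter of each other.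

Going by the values given here, compound 4 (`C=CC[C@H]1C[C@]2([C@@H](C)Cc3ccc(OC(F)(F)F)cc3)OCOC2=CC1=O`) keeps the shared core and differs from compound 3 by trifluoromethyl in place of hydrogen on an oxygen on an aromatic ring as its one change, trifluoromethyl in place of hydrogen on an oxygen on an aromatic ring. Among the compounds with values here, no measured step makes this exact change, so the evidence is indirect. The closest is an at least 2.0-fold higher number from compound 2 to compound 3 (0.31 log units; beyond the scatter) for hydroxy in place of hydrogen on an aromatic carbon, and its size is only a floor. Next comes an at least 1.8-fold higher number from compound 1 to compound 3 (0.27 log units; that floor lies within the scatter) as a second floor. The step of a 1.1-fold lower number from compound 1 to compound 2 (0.04 log units; within the scatter) for hydrogen in place of methoxy shows that the two compounds without hydroxy read alike.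

Compound 4 also lacks a hydroxy, so it is expected to read near compound 1 (10600 nM) and compound 2 (9700 nM). For compound 4 the expected step in this assay is an at least 2.2-fold lower number from compound 3 to compound 4 (0.34 log units; beyond the scatter) toward a lower number, although a reading at the limit remains possible. The estimate for compound 4 is 9000 nM (expected range 3500 nM to 20000 nM).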

Compound 4, half-maximal inhibitory concentration: 3800 nM
The estimate for compound 4 lay 2.4-fold (0.37 log units) above the measured number; low and high end bracket the measured number.
By their numbers in this assay, from the lowest: compound 4; then compounds 2 and 1 (each within the scatter of the next). At a limit, above all of these: compound 3.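

The earlier compounds had shown a hydroxy on this aromatic ring moving the number up, while compounds 1 and 2 read alike, so no change had yet lowered it. In this assay, trifluoromethyl in place of hydrogen on the oxygen gives an at least 5.2-fold lower number from compound 3 to compound 4 (0.72 log units; beyond the scatter), and the size of this step is only a floor because compound 3 reads at a limit of the assay: the limit of > 20000 nM in this assay, at which 1 of the 4 values shown sits. The change also lowers the number relative to the compound with no group at this place, a 2.6-fold lower number from compound 2 to compound 4 (0.41 log units; beyond the scatter), so at this aromatic carbon hydroxy and trifluoromethoxy shift the reading in opposite directions.

The compounds shown leave open whether other groups at this place, such as an amine or a carboxylic acid, would read like compound 4 or like compound 3. They also leave open whether trifluoromethoxy would lower the number in the same way if it stood where compound 1 carries its methoxy.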